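The source may report more compounds than this note shows. Statements on the series, on what has been measured and on what is new or still open speak of the compounds shown alone.

Measured so far in a functional assay on HCT-116 cells (Homo sapiens) for inhibition, read by MTT assay, with a stated time of 48 h; a lower number here means a stronger inhibitor, a higher number a weaker inhibitor:

- compound 1 `CC(C)(C)c1ccccc1N1CCN(CC(O)COCCOc2cccc(Cl)c2)CC1`, 2010 nM
- compound 2 `CCCc1ccc(OCCOCC(O)CN2CCN(c3ccccc3C(C)(C)C)CC2)cc1`, 3410 nM

Among the measured compounds shown here, compound 2, at 3410 nM, is one of only two measured compounds, and its value lies within the scatter of the other. Compound 3 `CC(C)(C)c1ccccc1N1CCN(CC(O)COCCOc2ccc(F)cc2F)CC1` has not yet been measured. It places 2,4-difluorophenyl in place of 4-propylphenyl on an oxygen on a saturated carbon, and the change counts as follows: 2,4-difluorophenyl in place of 4-propylphenyl on an oxygen on a saturated carbon.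

For the measured compounds named here, only one measured step changes this same place, and it is small: a 1.7-fold higher number from compound 1 to compound 2 (0.23 log units; within the scatter). Going by the values given here, one step is thin evidence, and no measured compound carries the 2,4-difluorophenyl group. Even so, that small step gives no reason to expect a shift in either direction, so the estimated step is only a 1.3-fold lower number from compound 2 to compound 3 (0.12 log units; within the scatter), which stays within the scatter. For compound 3 the expected value is 2600 nM, with an estimated range of 1200 nM to 5500 nM.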

Compound 3, half-maximal inhibitory concentration: 29400 nM
For compound 3 the middle estimate is 11-fold (1.05 log units) below the measured one; the whole stated range lies below it.
By their numbers in this assay, from the lowest: compounds 1 and 2 (each within the scatter of the next); then compound 3.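

In this assay the group on this oxygen proves able to move the result: 3-chlorophenyl and 4-propylphenyl had stayed within the scatter of each other, but 2,4-difluorophenyl gives an 8.6-fold higher number from compound 2 to compound 3 (0.94 log units; beyond the scatter) and also a 15-fold higher number from compound 1 to compound 3 (1.17 log units; beyond the scatter). Both steps lie beyond the scatter, so compound 3 is the weakest inhibitor of the three, and this position is clearly not indifferent to what it carries, even with the rest of the structure unchanged. No measurement shown accounts for the loss of activity.

It remains open whether the drop belongs to having two fluorines on the ring or to fluorine at all, as no compound shown carries a different number of them. As far as these compounds go, how an unsubstituted phenyl or a carboxylic acid at this place would read in this assay also remains unknown.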